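The compounds below may be only part of what the source reports. "The series", "measured", "known", "first", "only" and "open" are said of these compounds alone.

Measured so far in an ADME assay on HaCaT cells (Homo sapiens) for cytotoxicity, read by MTT assay, with a stated time of 72 h; on this read-out lower numbers stand for stronger inhibition and higher numbers for weaker inhibition:

Compound 1, `Cc1cc(S(=O)(=O)/N=C(\N)n2nccc2-c2ccccc2)c(SCc2ccccc2)cc1Cl`: 18000 nM
Compound 2, `Cc1cc(S(=O)(=O)/N=C(\N)n2nccc2-c2ccccc2)c(SCc2cccc3ccccc23)cc1Cl`: 11000 nM
Compound 3, `Cc1cc(S(=O)(=O)/N=C(\N)n2nccc2-c2ccccc2)c(SCc2cccc(C(F)(F)F)c2)cc1Cl`: 18000 nM

Compound 3 stands level with compound 1 at the digits given; the two share the highest number of the three, while the gap to compound 2 is within the scatter. From compound 1 the step reads no change at the digits printed from compound 1 to compound 3 (within the scatter), and from compound 2 it reads a 1.6-fold higher number from compound 2 to compound 3 (0.21 log units; within the scatter).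

Compound 4 is `Cc1ccc(CSc2cc(Cl)c(C)cc2S(=O)(=O)/N=C(\N)n2nccc2-c2ccccc2)cc1`. It differs from compound 3 in one place: 4-methylphenyl in place of 3-(trifluoromethyl)phenyl on a saturated chain carbon bound to a sulfur. All three measured steps touch the same position on the saturated chain carbon bound to a sulfur, or the aromatic ring attached there: a 1.6-fold lower number from compound 1 to compound 2 (0.21 log units; within the scatter), no change at the digits printed from compound 1 to compound 3 (within the scatter), and a 1.6-fold higher number from compound 2 to compound 3 (0.21 log units; within the scatter). None of them moves beyond the scatter, so the data give no reason to expect that exchanging one substituted phenyl for another at this place will do so either. Compound 4 is therefore expected to sit close to compound 3 in this assay, with a step of no change at the digits printed from compound 3 to compound 4 (within the scatter). The estimate for compound 4 is 18000 nM, expected to fall between 9000 nM and 36000 nM.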

Compound 4, half-maximal inhibitory concentration: 20000 nM
The estimate for compound 4 lay 1.1-fold (0.05 log units) below the measured number; low and high end bracket the measured number.
By their numbers in this assay, from the lowest: compounds 2, 1, 3 and 4 (each within the scatter of the next).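

In this assay, the exchange of 3-(trifluoromethyl)phenyl for 4-methylphenyl on a saturated chain carbon bound to a sulfur reads a 1.1-fold higher number from compound 3 to compound 4 (0.05 log units; within the scatter), so a ring carrying a methyl group now also stands within the scatter of one carrying trifluoromethyl, and the two groups also differ in where they sit on the ring. Methyl in place of hydrogen on the plain phenyl ring reads a 1.1-fold higher number from compound 1 to compound 4 (0.05 log units; within the scatter), and 4-methylphenyl in place of naphthalen-1-yl reads a 1.8-fold higher number from compound 2 to compound 4 (0.26 log units; within the scatter), the largest step at this place so far and still within the scatter, so none of the four aromatic groups shown separates from the others here. No measurement is at hand that could explain this lack of separation.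

From the compounds shown here alone, all four compounds carry a carbon-only aromatic ring at this place, so the reading for a carboxylic acid or an amine on that ring, or for a longer chain in place of the benzyl group, remains open. The shared core is also the same throughout, so these compounds do not show how a change elsewhere in the molecule would read in this assay.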